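This account rests on a few compounds, and the source may have more. Where it says the series, first, only, none or still open, it means among the compounds named here.

Working notes on the series.

Two compounds have numbers in a functional assay on M14 cells (Homo sapiens) for inhibition, read by sulforhodamine B assay, with a stated time of 48 h; a lower number here means a stronger inhibitor of growth, a higher number a weaker inhibitor of growth. Compound 1, `COc1ccc(-c2[nH]c3ccc(OC)cc3c2/C=C(\C#N)S(=O)(=O)c2ccccc2)cc1`, gives 500 nM in this assay. Compound 2, `CC(=O)/C(=C\c1c(-c2ccccc2)[nH]c2ccccc12)S(=O)(=O)c1ccccc1`, gives 521 nM in this assay. The two numbers lie within the scatter of each other, so the shared core carries about the same potency with either of the two substitution patterns shown, and neither compound can be called the stronger.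

Compound 3, `O=C(/C(=C\c1c(-c2ccccc2)[nH]c2ccccc12)S(=O)(=O)c1ccccc1)c1ccccc1`, is not yet measured in this assay. It differs from compound 2 in one place: phenyl in place of methyl on a carbonyl carbon, which read one bond further out is acetyl to benzoyl. Within the data shown here, no measured pair shows what such a change does, so the direction is open.

The step from compound 2 to compound 3 is expected to be small, a 1.2-fold lower number from compound 2 to compound 3 (0.06 log units; within the scatter), in either direction and likely not beyond the scatter.

Compound 3 is therefore estimated at 450 nM in this assay, with a range from 150 nM to 1500 nM.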

Compound 3, concentration for 50% growth inhibition: 15600 nM
For compound 3 the middle estimate is 35-fold (1.54 log units) below the measured one, and the stated range ends below it.
By their numbers in this assay, from the lowest: compounds 1 and 2 (each within the scatter of the next); then compound 3.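

In this assay, the carbonyl carbon proves to be a place where the series does not tolerate every group: phenyl in place of methyl gives a 30-fold higher number from compound 2 to compound 3 (1.48 log units; beyond the scatter) and so takes growth inhibition far from the level of compound 2. Among these compounds, this is the first one-place step, and it shows that the group on this carbonyl carbon can decide potency, which compounds 1 and 2 could not show with values that lie within the scatter of each other. Nothing available bears on the reason for this large step.

The compounds shown leave open what happens between methyl and phenyl on this carbon, for example with an ethyl group, a longer chain or a saturated cyclohexyl ring. On these data alone, it also remains open whether an amine or a carboxylic acid on the phenyl ring of compound 3 would bring the number back towards that of compound 2.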